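The compounds below may be only part of what the source reports. "The series", "measured", "known", "first", "only" and "open" are said of these compounds alone.

Compound 3 `CC(C)/C=N/NC(=O)c1ccc(O[C@@H]2O[C@H](CO)[C@@H](O)[C@H](O)[C@H]2O)cc1` is one of three glycosylated hydrazones tested in a functional assay on MDA-MB-231 cells (Homo sapiens) for inhibition, read by MTT assay, with a stated time of 24 h, tested at 100 uM (a higher number here means more inhibition at the concentration tested (going by the name of the read-out), a lower number less inhibition), where compound 3 gives 1.7%. Compound 1 `O=C(N/N=C/c1ccc([N+](=O)[O-])cc1)c1ccc(O[C@@H]2O[C@H](CO)[C@@H](O)[C@H](O)[C@H]2O)cc1` gives 7.12% in this assay, and compound 2 `O=C(N/N=C/c1ccccc1)c1ccc(O[C@@H]2O[C@H](CO)[C@@H](O)[C@H](O)[C@H]2O)cc1` gives 3.56%. Compound 3 sits at the lower end of these three numbers, but only within the scatter: the step of a number 5.4 percentage points lower from compound 1 to compound 3 (within the scatter) and the step of a number 1.9 percentage points lower from compound 2 to compound 3 (within the scatter) are both small, as is the step of a number 3.6 percentage points lower from compound 1 to compound 2 (within the scatter). Compound 4 `CCCCC/C=N/NC(=O)c1ccc(O[C@@H]2O[C@H](CO)[C@@H](O)[C@H](O)[C@H]2O)cc1` has not yet been measured. It differs from compound 3 in one place: pentyl in place of isopropyl on a carbon with a double bond to nitrogen. Going by the values given here, the steps that bear on this change are those that also alter the group on the carbon with a double bond to nitrogen, from compound 1 to compound 3 and from compound 2 to compound 3, and neither moved the number beyond the scatter. The expected step from compound 3 to compound 4 in this assay is therefore a number 0.8 percentage points higher from compound 3 to compound 4 (within the scatter), that is, none beyond the scatter. Compound 4 is estimated to give 2.5%, with a range from 0% to 10%.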

Compound 4, a percentage reported as inhibition, at one concentration (the size of the read-out at that concentration, not a potency): 11%
Estimate against measurement, compound 4: 8.5 percentage points below; measured number above the stated range.
By their numbers in this assay, from the lowest: compounds 3, 2, 1 and 4 (each within the scatter of the next).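

In this assay, going by these compounds alone, the exchange of isopropyl for pentyl on a carbon with a double bond to nitrogen gives a number 9.3 percentage points higher from compound 3 to compound 4 (within the scatter) and is the largest step seen at this position so far, yet it does not leave the scatter. The exchanges from the aromatic groups give a number 7.4 percentage points higher from compound 2 to compound 4 (within the scatter) and a number 3.9 percentage points higher from compound 1 to compound 4 (within the scatter) and so also stay inside it, which means that pentyl, isopropyl, phenyl and 4-nitrophenyl cannot be told apart at this position. Nothing on hand gives a reason for the size of these steps.

Going by these compounds, whether a longer chain such as octyl would give a step beyond the scatter remains open. The same holds for a chain ending in an amine or a carboxylic acid.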